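Dimethoxyphenyl in Place of Furan on the Shared Core

The compounds below may be only part of what the source reports. "The series", "measured", "known", "first", "only" and "open" are said of these compounds alone.

Measured compounds:
Compound 1, `COc1ccc(C2CC(c3ccc(OC)c(OC)c3)=NN2)c(OC)c1`: 38%
Compound 2, `COc1ccc(C2CC(c3ccc(OC)c(OC)c3)=NN2C(=O)CO[N+](=O)[O-])c(OC)c1`: 38%
Compound 3, `COc1ccc(C2=NN(C(=O)C(C)Br)C(c3ccco3)C2)cc1OC`: 22%

All three were tested in a functional assay on the whole organism (strain albino) for inhibition, with Rattus norvegicus as the target, read by paw edema, with stated times of 30 min and 1 h, at a dose of 100 mg/kg by the oral route; a higher number here means more inhibition at the dose given (going by the name of the read-out), a lower number less inhibition. In this assay compound 1 gives 38%, compound 2 gives 38% and compound 3 gives 22%. Compound 3 stands lowest of the three numbers; its gap to compound 1 and its gap to compound 2 are both beyond the usual scatter of this measurement.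

Compound 4, `COc1ccc(C2CC(c3ccc(OC)c(OC)c3)=NN2C(=O)C(C)Br)c(OC)c1`, has not yet been measured. It differs from compound 3 by 2,4-dimethoxyphenyl in place of furan-2-yl on a saturated ring carbon. For the measured compounds named here, the only measured step, no change at the digits printed from compound 1 to compound 2 (within the scatter), concerns the ring nitrogen rather than this saturated ring carbon, so no measured step bears directly on the change at hand. What the numbers do show is that compound 1 and compound 2, which both carry the 2,4-dimethoxyphenyl group on that carbon, sit above compound 3. Compound 4 is therefore expected to move upward from compound 3, a step of a number 13 percentage points higher from compound 3 to compound 4 (beyond the scatter), because compound 1 gives 38% and compound 2 gives 38%. For compound 4 the estimate in this assay is 35%, within a range from 22% to 48%.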

Compound 4, a percentage reported as inhibition, in the whole organism at one dose (the size of the read-out at that dose, not a potency): 58%
Estimate against measurement, compound 4: 23 percentage points below; the measured number lies above the stated range.
By their numbers in this assay, from the lowest: compound 3; then compounds 1 and 2 (each within the scatter of the next); then compound 4.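

In this assay, the saturated ring carbon proves sensitive to the group it carries: 2,4-dimethoxyphenyl in place of furan-2-yl gives a number 36 percentage points higher from compound 3 to compound 4 (beyond the scatter), a large step and the first measured at this position. The acyl group on the ring nitrogen can also matter, which the earlier step, no change at the digits printed from compound 1 to compound 2 (within the scatter), did not show: (1-bromoethyl)carbonyl in place of hydrogen gives a number 20 percentage points higher from compound 1 to compound 4 (beyond the scatter), and 1-bromoethyl in place of (nitrooxy)methyl on the carbonyl carbon gives a number 20 percentage points higher from compound 2 to compound 4 (beyond the scatter), both modest steps. No measurement offered here accounts for either gain.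

For the compounds shown here, the exchange of furan-2-yl for 2,4-dimethoxyphenyl is seen only with (1-bromoethyl)carbonyl on the ring nitrogen, so its size with hydrogen or ((nitrooxy)methyl)carbonyl there remains open. As far as these compounds go, it is also open whether the gain depends on the bromine or on the two methoxy groups, which a chloroethyl chain on the carbonyl or a plain phenyl ring on the saturated ring carbon would begin to test.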